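The source may report more compounds than this note shows. Statements on the series, on what has been measured and on what is new or still open speak of the compounds shown alone.

Three compounds have numbers in an assay on isolated protein for inhibition of Aromatase (Homo sapiens), read by fluorescence and colorimetric assay, with a stated time of 30 min; a higher number here means a weaker inhibitor, a lower number a stronger inhibitor: compound 1 `CCCc1cn(C(c2ccccc2)c2ccccc2)nn1` gives 11000 nM; compound 2 `N#Cc1ccc(Cn2cc(C3CCCCC3)nn2)cc1` gives 10700 nM; compound 3 `CCCc1cn(Cc2ccccc2)nn1` gives 12600 nM.

Compound 3 shows the highest of the three numbers, yet its gaps to compound 1 and to compound 2 are both within the scatter, so the three cannot be set in order. Among the compounds with values here, the one measured step, a 1.1-fold higher number from compound 1 to compound 3 (0.06 log units; within the scatter), changes the group on the saturated carbon bound to the ring nitrogen and moves nothing.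

Compound 4 `c1ccc(Cn2cc(C3CCCCC3)nn2)cc1` is the next compound. It differs from compound 3 in cyclohexyl in place of propyl on an aromatic carbon. Within the data shown here, no measured step touches this position. Compound 2 carries the same cyclohexyl group, with a nitrile on its benzyl ring, and the numbers of compound 2 and compound 3 lie within the scatter of each other. On that basis compound 4 is expected to stay close to compound 3, with a step of about a 1.1-fold lower number from compound 3 to compound 4 (0.06 log units; within the scatter) in this assay. The estimate for compound 4 is 11000 nM, in the range 5000 nM to 25000 nM.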

Compound 4, half-maximal inhibitory concentration: 7980 nM
The estimate for compound 4 lay 1.4-fold (0.14 log units) above the measured number, and the stated range covers the measured number.
By their numbers in this assay, from the lowest: compounds 4, 2, 1 and 3 (each within the scatter of the next).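

Cyclohexyl in place of propyl on the aromatic carbon gives the first measured step at this position, a 1.6-fold lower number from compound 3 to compound 4 (0.20 log units; within the scatter), so in this assay a group of 6 heavy atoms with a six-membered ring, in place of a chain of 3, leaves the number within the scatter. Hydrogen in place of cyano on an aromatic carbon of the benzyl ring gives a 1.3-fold lower number from compound 2 to compound 4 (0.13 log units; within the scatter), which shows that the nitrile does not move the number beyond the scatter when cyclohexyl is present. No evidence on hand bears on either result.

The compounds shown leave open whether any group on this aromatic carbon can move the number beyond the scatter. An amine, a carboxylic acid or a longer chain there might do so, and the values here give no indication either way.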